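Trimming one sulfonamide substituent

The compounds below may be only part of what the source reports. "The series", "measured", "known", "first", "only" and "open" are said of these compounds alone.

Measured in an ADME assay on a cell-free system (plasma, Homo sapiens); on this read-out lower numbers stand for a smaller free fraction and higher numbers for a larger free fraction:
- compound 1 `Cc1ccc(S(=O)(=O)N(C)C(C)C)cc1C#Cc1cc(Cl)ccc1OCC(=O)O` gives 0.002 as its value
- compound 2 `O=C(O)COc1ccc(Cl)cc1C#Cc1cccnc1` gives 0.029 as its value

Among the compounds with values here, of these two numbers, the one for compound 1 (0.002) is the lower, and the gap to compound 2 (0.029) lies beyond the usual scatter. Compound 3 `Cc1ccc(S(=O)(=O)N(C)C)cc1C#Cc1cc(Cl)ccc1OCC(=O)O` keeps the core of compound 1 and differs in one place, with methyl in place of isopropyl on a sulfonamide nitrogen. Within the data shown here, no pair of measured compounds shows this change, so the data offer no direct guide to its size. Only a modest rise in this assay is expected, given how little of the structure changes. The estimated step of a 1.8-fold higher number from compound 1 to compound 3 (0.24 log units; within the scatter) is small and upward, and may not exceed the scatter. In this assay compound 3 is expected at 0.0035 (estimated range 0.002 to 0.007).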

Compound 3, unbound fraction: 0.004
Estimate against measurement, compound 3: 1.1-fold (0.06 log units) below; measured number inside the range.
By their numbers in this assay, from the lowest: compounds 1 and 3 (each within the scatter of the next); then compound 2.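

In this assay, the change from isopropyl (3 heavy atoms) to methyl (1 heavy atom) on the sulfonamide nitrogen gives a 2.0-fold higher number from compound 1 to compound 3 (0.30 log units; within the scatter). Within the data shown here, this is the first direct look at this position, and it shows that this trim, made on its own, does not separate the two compounds beyond the usual scatter of repeated measurements. No measurement shown here gives a reason for this outcome.

Among these compounds, this single pair covers only one change at this position, so it cannot establish a trend with substituent size. Going by these compounds, whether a hydrogen, an ethyl group or a longer chain carrying an amine on that nitrogen would give a step beyond the scatter remains open.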